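A few compounds are considered here, and "the series" means these few. Any claim that something is new, unique, unknown or untested is made for them only; others in the source may bear on it.

Working notes on a series built on one shared core. Compound 1 `CN1CCC[C@H]1COc1cncc(-c2cccc(N)c2)c1` gives 0.43 nM in an assay on membranes from brain for binding affinity to Neuronal acetylcholine receptor; alpha4/beta2 (Rattus norvegicus); on this read-out higher numbers stand for weaker inhibition and lower numbers for stronger inhibition. Compound 2 `CN1CCC[C@H]1COc1cncc(-c2ccc(F)cc2)c1` gives 0.11 nM in this assay, and compound 3 `Cc1ccc(-c2cncc(OC[C@@H]3CCCN3C)c2)cc1` gives 0.13 nM in this assay. Among the three numbers compound 3 stands with compound 2 within the scatter of each other, and both sit clearly apart from compound 1: a 3.9-fold lower number from compound 1 to compound 2 (0.59 log units; beyond the scatter), a 3.3-fold lower number from compound 1 to compound 3 (0.52 log units; beyond the scatter), and a 1.2-fold higher number from compound 2 to compound 3 (0.07 log units; within the scatter).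

Compound 4 `CN1CCC[C@H]1COc1cncc(-c2ccc(Cl)cc2)c1` is not yet measured. It differs from compound 3 in a single place: chloro in place of methyl on an aromatic carbon. For the measured compounds named here, the one measured step that bears directly on this place is the exchange of one small group for another on the same aromatic carbon, a 1.2-fold higher number from compound 2 to compound 3 (0.07 log units; within the scatter), which stayed within the scatter. The two steps away from compound 1, a 3.9-fold lower number from compound 1 to compound 2 (0.59 log units; beyond the scatter) and a 3.3-fold lower number from compound 1 to compound 3 (0.52 log units; beyond the scatter), exchange the whole aromatic group and say less about this single spot. On that basis compound 4 is expected to land close to compound 3 in this assay, with no step beyond the scatter. For compound 4 the expected step is a 1.1-fold lower number from compound 3 to compound 4 (0.03 log units; within the scatter). The estimate for compound 4 is 0.12 nM, in a range from 0.05 nM to 0.3 nM.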

Compound 4, inhibition constant: 0.082 nM
The estimate for compound 4 lay 1.5-fold (0.17 log units) above the measured number; the range from low to high includes it.
By their numbers in this assay, from the lowest: compounds 4, 2 and 3 (each within the scatter of the next); then compound 1.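

The aromatic carbon para to a large group now carries fluoro, methyl or chloro, and in this assay the exchange of chloro for either of the other two stays within the scatter (a 1.6-fold lower number from compound 3 to compound 4 (0.20 log units; within the scatter); a 1.3-fold lower number from compound 2 to compound 4 (0.13 log units; within the scatter)). Together with the earlier exchange of methyl for fluoro, this shows that no pair among these three single-atom or single-carbon groups can be told apart at this position, so compounds 2, 3 and 4 read as one level. The 4-chlorophenyl group also stands clearly apart from the 3-aminophenyl group of compound 1 (a 5.2-fold lower number from compound 1 to compound 4 (0.72 log units; beyond the scatter)), as the 4-fluorophenyl and 4-methylphenyl groups do, though nothing at hand accounts for any of these numbers.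

As far as these compounds go, what remains open is whether this level holds for larger or different groups on the same carbon, such as methoxy, trifluoromethyl, a carboxylic acid or a longer alkyl chain. The step from compound 1 also changes both the group and where it sits on the ring, so a 4-aminophenyl group would be needed to separate the amine from its placement.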